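Trifluoromethyl for Fluoro on the Benzyl Arm

The source may report more compounds than this note shows. Statements on the series, on what has been measured and on what is new or still open speak of the compounds shown alone.

Compound 3 `Nc1cc(-c2cc3c(=O)n(Cc4cccc(F)c4)cnc3s2)ccn1` gives 5 nM in an assay on isolated protein for inhibition of Rho-associated protein kinase 2 (Homo sapiens), read by radiometric assay and 33P incorporation, with a stated time of 40 min, in the presence of a further agent that is not named here; a higher number here means a weaker inhibitor, a lower number a stronger inhibitor. Among the three measured compounds it holds the second highest number: compound 2 `O=c1c2cc(-c3ccnc4[nH]ccc34)sc2ncn1Cc1cccc(C(F)(F)F)c1` gives 7 nM, which lies within the scatter of compound 3, while compound 1 `COc1cccc(Cn2cnc3sc(-c4ccnc(N)c4)cc3c2=O)c1` gives 1 nM, and the step of a 5.0-fold higher number from compound 1 to compound 3 (0.70 log units; beyond the scatter) lies beyond the scatter. Compound 4 `Nc1cc(-c2cc3c(=O)n(Cc4cccc(C(F)(F)F)c4)cnc3s2)ccn1` differs from compound 3 in one place: trifluoromethyl in place of fluoro on an aromatic carbon, on an aromatic carbon of a six-membered aromatic ring of carbon only, meta to a large group. Among the compounds with values here, no measured pair shows exactly this change. Within the data shown here, the only step at the same place, a 5.0-fold higher number from compound 1 to compound 3 (0.70 log units; beyond the scatter), was modest. Compound 2 carries a trifluoromethyl on the same arm but a different group on the other side of the shared core, and its value and that of compound 3 are within the scatter of each other. The step of a 1.2-fold higher number from compound 3 to compound 4 (0.08 log units; within the scatter) is therefore expected to stay within the scatter. Compound 4 is estimated at 6 nM, with a range from 2 nM to 18 nM.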

Compound 4, half-maximal inhibitory concentration: 25 nM
Beside the measured number, compound 4's estimate is 4.2-fold (0.62 log units) below it, and the stated range ends below it.
By their numbers in this assay, from the lowest: compound 1; then compounds 3 and 2 (each within the scatter of the next); then compound 4.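

In this assay, the three compounds that differ only on the benzyl arm now form an order running from methoxy through fluoro to trifluoromethyl: compound 3 to compound 4 adds a second clear rise, a 5.0-fold higher number from compound 3 to compound 4 (0.70 log units; beyond the scatter), after a 5.0-fold higher number from compound 1 to compound 3 (0.70 log units; beyond the scatter). Across the whole series, the change at this aromatic carbon amounts to a 25-fold higher number from compound 1 to compound 4 (1.40 log units; beyond the scatter), a large effect from a single substituent. The pair sharing the trifluoromethyl arm also shows that the other side of the shared core matters, with a 3.6-fold higher number from compound 2 to compound 4 (0.55 log units; beyond the scatter), so the group of 9 heavy atoms gives the lower number with this arm.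

Nothing available here accounts for these steps. On these data alone, how an amine or a hydroxyl at this aromatic carbon would compare with methoxy remains open, as does whether methoxy would give the same order with the group of 9 heavy atoms.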